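Moving chlorine from 2-chlorophenyl to 4-chlorophenyl

The source may hold more compounds than are shown below. What is called first, only, known or untested is meant among the compounds shown, and "the series" means these compounds.

Within the data shown here, compound 2 `CC1=CC[C@H](C(C)(C)NC(=S)N/N=C/c2ccccc2Cl)CC1` gives 19300 nM in a functional assay on UACC-62 cells (Homo sapiens) for inhibition, read by sulforhodamine B assay, with a stated time of 48 h (on this read-out lower numbers stand for stronger inhibition of growth and higher numbers for weaker inhibition of growth), the lowest of the two numbers so far; compound 1 `CC1=CC[C@H](C(C)(C)NC(=S)N/N=C/c2ccccc2)CC1` gives 31600 nM, and the step of a 1.6-fold lower number from compound 1 to compound 2 (0.21 log units; within the scatter) lies within the scatter. Compound 3 `CC1=CC[C@H](C(C)(C)NC(=S)N/N=C/c2ccc(Cl)cc2)CC1` differs from compound 2 only in this: 4-chlorophenyl in place of 2-chlorophenyl on a carbon with a double bond to nitrogen. Among the measured compounds shown here, no measured step shows the effect of shifting the chlorine around the ring, and the single measured step is itself within the scatter. Compound 3 is therefore expected to give a number close to that of compound 2, with the step of a 1.0-fold higher number from compound 2 to compound 3 (0.02 log units; within the scatter) estimated to stay within the scatter. The estimate for compound 3 is 20000 nM, in the range 8000 nM to 50000 nM.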

Compound 3, concentration for 50% growth inhibition: 11200 nM
Beside the measured number, compound 3's estimate is 1.8-fold (0.25 log units) above it, within the range that was stated.
By their numbers in this assay, from the lowest: compounds 3, 2 and 1 (each within the scatter of the next, the first and the last beyond it).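

In this assay, the shift from 2-chlorophenyl to 4-chlorophenyl on a carbon with a double bond to nitrogen stays within the scatter (a 1.7-fold lower number from compound 2 to compound 3 (0.24 log units; within the scatter)), so the two placements of chlorine cannot be told apart. Chloro in place of hydrogen on an aromatic carbon now gives a modest step beyond the scatter (a 2.8-fold lower number from compound 1 to compound 3 (0.45 log units; beyond the scatter)), which the earlier step from the unsubstituted phenyl compound did not. No evidence on the cause of either step is available. Going by these compounds, whether an amine or a carboxylic acid in place of the chloro would give a lower or a higher number stays open.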